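Two Weak Inhibitors of Growth and a Smaller Ring

A few compounds are considered here, and "the series" means these few. Any claim that something is new, unique, unknown or untested is made for them only; others in the source may bear on it.

Compound 2, `CC(=O)N1CCN(c2nc(Nc3ccc(C#N)c(C(F)(F)F)c3)nc(Oc3ccnc4ccccc34)n2)CC1`, was tested in a functional assay on DU-145 cells (Homo sapiens) for cytotoxicity, read by sulforhodamine B assay, with a stated time of 48 h; on this read-out lower numbers stand for stronger inhibition of growth and higher numbers for weaker inhibition of growth. Among the compounds with values here, in that test compound 2 gives 75100 nM, and this is the only plain number among the values shown. Compound 1, `N#Cc1ccc(Nc2nc(Oc3ccnc4ccccc34)nc(N3CCN(C(c4ccccc4)c4ccc(Cl)cc4)CC3)n2)cc1C(F)(F)F`, reaches only a limit of the test: compound 1 gives > 100000 nM in this assay. That outcome is summed up as the limit of > 100000 nM in this assay, at which 1 of the 2 values shown sits. Within the data shown here, no step between two measured compounds that differ in a single place has been measured, so nothing measured says how large a single change can move the result here. Compound 3, `N#Cc1ccc(Nc2nc(Oc3ccnc4ccccc34)nc(N3CCCCC3)n2)cc1C(F)(F)F`, differs from compound 2 in one place: piperidin-1-yl in place of 4-acetylpiperazin-1-yl on an aromatic carbon. Because compound 2 gives 75100 nM in this assay, the step from compound 2 to compound 3 is expected to stay within the usual scatter, as a 1.3-fold lower number from compound 2 to compound 3 (0.10 log units; within the scatter). Compound 3 is therefore expected to give about 60000 nM in this assay, with a plausible range from 20000 nM to 200000 nM, and a fair chance that only a limit is reported.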

Compound 3, concentration for 50% growth inhibition: 94900 nM
Compound 3: the middle estimate sits 1.6-fold (0.20 log units) below what was measured; the range from low to high includes it.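

Within the data shown here, this is the first step between two compounds that differ in one place, and in this assay putting piperidin-1-yl in place of 4-acetylpiperazin-1-yl on the carbon opposite the ring nitrogen gives a 1.3-fold higher number from compound 2 to compound 3 (0.10 log units; within the scatter). At this position, then, going from a group of 9 heavy atoms to one of 6, with the acetyl group and one ring nitrogen gone, does not move the result beyond the usual scatter, and neither compound shows strong inhibition of growth. Compound 1 remains a limit of the test rather than a number, so its steps to the other two compounds cannot be read: the limit of > 100000 nM in this assay, at which 1 of the 3 values shown sits.

The compounds shown leave open whether any group at this position can bring the result into a much lower range, such as a small open-chain amine like dimethylamino, or a piperazine ring with a free hydrogen on its outer nitrogen. They also leave open what a change elsewhere on the shared core would do, for example a simple methoxy group in place of the (quinolin-4-yl)oxy group.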